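From Benzyl to Phenyl on the Shared Core

The source may hold more compounds than are shown below. What is called first, only, known or untested is meant among the compounds shown, and "the series" means these compounds.

In a functional assay on Cortical neurone cells (Mus musculus, strain C57BL/6), read by FLIPR and calcium flux, with a stated time of 8 min (on this read-out lower numbers stand for stronger inhibition and higher numbers for weaker inhibition), compound 3 (`Cc1ccc(Cc2nc3[nH]c(Cc4ccccc4)cc(=O)n3n2)cc1`) gives 2470 nM. Compound 1 (`O=c1cc(Cc2ccccc2)[nH]c2nc(Cc3ccc(Cl)cc3)nn12`), at 4280 nM, lies within the scatter of that number. Compound 2 (`CCCCCc1nc2[nH]c(-c3ccc(Cl)cc3)cc(=O)n2n1`), at 8250 nM, has a higher number, and it is the only one of the three beyond the scatter from compound 3.

The next compound, compound 4 (`Cc1ccc(Cc2nc3[nH]c(-c4ccccc4)cc(=O)n3n2)cc1`), carries phenyl in place of benzyl on an aromatic carbon. Among the compounds with values here, the only measured step, a 1.7-fold lower number from compound 1 to compound 3 (0.24 log units; within the scatter), is methyl in place of chloro elsewhere on the molecule, so it does not address this change. The nearest evidence is compound 2, which also has a ring attached directly at this place and gives 8250 nM. Compound 2 differs from compound 4 in other ways as well, including its pentyl chain, so it offers only a weak hint. Within the data shown here, no measured pair isolates phenyl against benzyl.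

A small shift towards a higher number in this assay is therefore expected, and it may not clear the scatter. The expected change is a 1.6-fold higher number from compound 3 to compound 4 (0.21 log units; within the scatter). Compound 4 is estimated at 4000 nM, with an expected range of 1500 nM to 10000 nM.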

Compound 4, half-maximal inhibitory concentration: 1150 nM
Beside the measured number, compound 4's estimate is 3.5-fold (0.54 log units) above it; measured number outside the range, below it.
By their numbers in this assay, from the lowest: compound 4; then compounds 3, 1 and 2 (each within the scatter of the next, the first and the last beyond it).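

Shortening the group on this aromatic carbon from benzyl to phenyl, which places the ring directly on the shared core, gives a real change in this assay with a 2.1-fold lower number from compound 3 to compound 4 (0.33 log units; beyond the scatter) as a modest step. Within the data shown here, the only step available earlier, a 1.7-fold lower number from compound 1 to compound 3 (0.24 log units; within the scatter) for methyl in place of chloro elsewhere on the molecule, stayed within the scatter and said nothing about this position. The new step is therefore the first single change among these compounds to move the number beyond the scatter, and it shows that this position responds to the group it carries, with the directly attached phenyl giving the lower number. No measurement available here accounts for this step, which stands as an observation only.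

The compounds shown leave open whether phenyl would give a similar step with chloro in place of methyl elsewhere on the molecule, or with a pentyl chain there. They also leave open how this aromatic carbon would respond to a group without a carbon ring, such as an amine, a carboxylic acid or a longer chain.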